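Shortening the linker and swapping the aryl amide in compound 2

The source may report more compounds than this note shows. Statements on the series, on what has been measured and on what is new or still open speak of the compounds shown alone.

Measured so far:
- compound 1 `O=S(=O)(NCCCNc1nccc(-c2c(-c3cccc(F)c3)nc3sccn23)n1)c1ccc(Br)cc1`: 7040 nM
- compound 2 `O=C(NCCCNc1nccc(-c2c(-c3cccc(F)c3)nc3sccn23)n1)c1ccc(F)cc1`: 14900 nM
- compound 3 `O=C(NCCNc1nccc(-c2c(-c3cccc(F)c3)nc3sccn23)n1)c1c(F)cccc1F`: 2700 nM

In a functional assay on A-375 cells (Homo sapiens) for cytotoxicity, read by MTT assay (on this read-out higher numbers stand for weaker inhibition and lower numbers for stronger inhibition), compound 2 gives 14900 nM, the highest of the three numbers, so it is the weakest inhibitor shown. Compound 4 `Cc1ccc(C(=O)NCCNc2nccc(-c3c(-c4cccc(F)c4)nc4sccn34)n2)cc1` differs from compound 2 by ((4-methylphenyl)carbonyl)amino in place of (((4-fluorophenyl)carbonyl)amino)methyl on a saturated chain carbon, two bonds along the chain from a nitrogen on an aromatic ring. The most comparable measured step is a 5.5-fold lower number from compound 2 to compound 3 (0.74 log units; beyond the scatter), which also shortens the chain while changing the aryl amide; a 2.6-fold lower number from compound 1 to compound 3 (0.42 log units; beyond the scatter) points the same way. A lower number, beyond the scatter, is therefore expected for compound 4, though a step of a 2.7-fold lower number from compound 2 to compound 4 (0.43 log units; beyond the scatter) is estimated to be smaller than the step to compound 3. Compound 4 is thus expected to give about 5500 nM, within a range of 2200 nM to 14000 nM.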

Compound 4, half-maximal inhibitory concentration: 5880 nM
Compound 4: middle estimate off by 1.1-fold (0.03 log units), on the low side; the range from low to high includes it.
By their numbers in this assay, from the lowest: compound 3; then compounds 4 and 1 (each within the scatter of the next); then compound 2.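

In this assay the shortened chain also lowers the number with a 4-methylphenyl amide (a 2.5-fold lower number from compound 2 to compound 4 (0.40 log units; beyond the scatter)), so the drop seen with compound 3 does not require the 2,6-difluorophenyl group. On that same chain, the aryl group still matters (a 2.2-fold higher number from compound 3 to compound 4 (0.34 log units; beyond the scatter)). The amide of compound 4 and the longer sulfonamide of compound 1 cannot be told apart (a 1.2-fold lower number from compound 1 to compound 4 (0.08 log units; within the scatter)).

Still open, on these data alone, is how much of the first step comes from the chain and how much from methyl replacing fluorine, and how a pyridine ring in place of the aryl group would read. No measurement shown here accounts for these differences.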